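Cytotoxicity notes: replacing the methanesulfonamide in a biaryl series

The source may hold more compounds than are shown below. What is called first, only, known or untested is meant among the compounds shown, and "the series" means these compounds.

Measured so far:
compound 1 `Cc1ccc(-c2c(C)c(-c3ccc(C)c(C)c3)c(C(OC(C)(C)C)C(=O)O)c(C)c2NS(C)(=O)=O)cc1C`: 15000 nM
compound 2 `Cc1ccc(-c2c(C)c(-c3ccc4c(c3)CCCO4)c(C(OC(C)(C)C)C(=O)O)c(C)c2NS(C)(=O)=O)cc1C`: 28000 nM

In an ADME assay on MT4 cells (Homo sapiens) for cytotoxicity, read by MTT assay, with a stated time of 4 days (on this read-out lower numbers stand for higher toxicity in this test and higher numbers for lower toxicity in this test), compound 1 gives 15000 nM and compound 2 gives 28000 nM; the step of a 1.9-fold higher number from compound 1 to compound 2 (0.27 log units; within the scatter) keeps the two within the scatter of each other. Compound 3 `Cc1ccc(-c2c(C)c(-c3ccc(C)c(C)c3)c(C(OC(C)(C)C)C(=O)O)c(C)c2NC(=O)Nc2ccccc2)cc1C` carries phenylcarbamoyl in place of methylsulfonyl on a nitrogen on an aromatic ring. Among the measured compounds shown here, the single measured step concerns the aromatic ring on the other side of the core and does not touch the nitrogen, so no measured step bears on this change. With nothing to lean on, a number near compound 1 is expected, and the expected step of a 1.3-fold lower number from compound 1 to compound 3 (0.10 log units; within the scatter) stays within the scatter. For compound 3 the estimate in this assay is 12000 nM, with a range from 4000 nM to 40000 nM.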

Compound 3, half-maximal cytotoxic concentration: 8000 nM
Beside the measured number, compound 3's estimate is 1.5-fold (0.18 log units) above it, and the stated range covers the measured number.
By their numbers in this assay, from the lowest: compounds 3, 1 and 2 (each within the scatter of the next, the first and the last beyond it).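

At the nitrogen on an aromatic ring, phenylcarbamoyl in place of methylsulfonyl stays within the scatter in this assay (a 1.9-fold lower number from compound 1 to compound 3 (0.27 log units; within the scatter)). Among the compounds shown here, this is the first measured step at this nitrogen, and it shows that the methylsulfonyl can be exchanged for a group carrying an aromatic ring without a change beyond the scatter. Nothing available bears on the reason for this result. Still open, from the compounds shown here alone, is how a free amine or an acetyl on this nitrogen would read. Also open, going by these compounds, is whether phenylcarbamoyl gives a similar reading when combined with the other aromatic group of compound 2.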